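Sulfonamide aryl exchange on a shared benzoxazole-free described core

A few compounds are considered here, and "the series" means these few. Any claim that something is new, unique, unknown or untested is made for them only; others in the source may bear on it.

Compound 3 `O=S(=O)(Nc1ccc2oc(-c3ccccc3)nc2c1)c1ccccc1Cl` carries a 2-chlorophenyl group on the sulfonyl sulfur. In an ADME assay on HEK293 cells (Homo sapiens) for cytotoxicity, read by resazurin assay, with a stated time of 48 h (on this read-out higher numbers stand for lower toxicity in this test and lower numbers for higher toxicity in this test), compound 3 gives 73000 nM. Compound 1 `Cc1ccccc1S(=O)(=O)Nc1ccc2oc(-c3ccccc3)nc2c1` differs only in a methyl in place of the chloro, and in this assay compound 1 gives 57000 nM; the step of a 1.3-fold higher number from compound 1 to compound 3 (0.11 log units; within the scatter) is within the scatter, so the two compounds stand together. Compound 2 `CS(=O)(=O)Nc1ccc(-c2nc3ccccc3o2)cc1` in this assay gives > 100000 nM, which is a limit of the assay and not a number (the limit of > 100000 nM in this assay, at which 1 of the 3 values shown sits).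

Compound 4 `Cc1cccc(S(=O)(=O)Nc2ccc3oc(-c4ccccc4)nc3c2)c1` is the next step: 3-methylphenyl in place of 2-chlorophenyl on a sulfonyl sulfur. Within the data shown here, the only measured step that bears on this, from compound 1 to compound 3, swapped methyl and chloro at one place on the phenyl and produced no change beyond the scatter. Moving a methyl to another place on the same phenyl is therefore expected to leave the number roughly where it is, as a 1.2-fold lower number from compound 3 to compound 4 (0.09 log units; within the scatter). Compound 4 is estimated at 60000 nM, between 30000 nM and 120000 nM.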

Compound 4, half-maximal cytotoxic concentration: 69000 nM
The estimate for compound 4 lay 1.2-fold (0.06 log units) below the measured number; measured number inside the range.
By their numbers in this assay, from the lowest: compounds 1, 4 and 3 (each within the scatter of the next). At a limit, above all of these: compound 2.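

In this assay, exchanging 2-chlorophenyl for 3-methylphenyl on the sulfonyl sulfur gives a 1.1-fold lower number from compound 3 to compound 4 (0.02 log units; within the scatter) and so changes both the substituent and its place on the phenyl without leaving the scatter. Moving the methyl alone, which the earlier compounds did not test, gives a 1.2-fold higher number from compound 1 to compound 4 (0.08 log units; within the scatter) and places 2-methylphenyl and 3-methylphenyl together. Among compounds 1, 3 and 4, neither the kind of substituent nor its place on this phenyl has shifted the number beyond the scatter, and nothing shown here gives a reason for this.

As far as these compounds go, it remains open whether a phenyl carrying an amine or a carboxylic acid would stand with these three compounds. The same is open for a longer chain in place of the phenyl on the sulfonyl sulfur.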